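The source may report more compounds than this note shows. Statements on the series, on what has been measured and on what is new or still open speak of the compounds shown alone.

Of the compounds shown here, three have been measured in a functional assay on MCF7 cells (Homo sapiens) for antiproliferative activity, read by CCK-8 assay, with a stated time of 72 h; on this read-out higher numbers stand for weaker inhibition of growth and lower numbers for stronger inhibition of growth. Compound 1 `CCC1C(=O)N(C)c2cnc(-n3ccc4cc(C(=O)NC)ccc43)nc2N1c1ccn(C)n1` gives 35400 nM, compound 3 `CCCCNC(=O)c1ccc2c(ccn2-c2ncc3c(n2)N(c2ccn(C)n2)C(CC)C(=O)N3C)c1` gives 8990 nM, and compound 2 `CC[C@@H]1C(=O)N(C)c2cnc(-n3ccc4cc(C(=O)NC(C)C)ccc43)nc2N1C1CCCC1` gives 1670 nM. On these numbers compound 2 stands lowest, so it is the strongest grower-inhibitor of the three, with compound 3 the nearest to it and compound 1 the furthest away.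

Compound 4 `CCNC(=O)c1ccc2c(ccn2-c2ncc3c(n2)N(C2CCCC2)[C@H](CC)C(=O)N3C)c1` has not yet been measured. It differs from compound 2 in one place only: hydrogen in place of methyl on a saturated chain carbon bound to an amide-type nitrogen and a saturated chain carbon.

Within the data shown here, only one measured step touches the same kind of place. Going from compound 1 to compound 3, a 3.9-fold lower number from compound 1 to compound 3 (0.60 log units; beyond the scatter), where a larger chain on that carbon went with a lower number. Compound 4 carries a smaller chain than compound 2, so a modest move in the other direction, toward a higher number, is expected, though it may not clear the usual scatter. The expected step from compound 2 to compound 4 is a 1.7-fold higher number from compound 2 to compound 4 (0.22 log units; within the scatter). Compound 4 is therefore estimated at 2800 nM in this assay, within a range of 1200 nM to 6500 nM.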

Compound 4, concentration for 50% growth inhibition: 784 nM
Beside the measured number, compound 4's estimate is 3.6-fold (0.55 log units) above it, and the stated range ends above it.
By their numbers in this assay, from the lowest: compound 4; then compound 2; then compound 3; then compound 1.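

In this assay, cutting isopropylcarbamoyl back to ethylcarbamoyl gives a 2.1-fold lower number from compound 2 to compound 4 (0.33 log units; beyond the scatter), so here a smaller group at this place goes with stronger inhibition of growth. The only earlier step at this kind of place, a 3.9-fold lower number from compound 1 to compound 3 (0.60 log units; beyond the scatter), ran the other way, with a longer chain going with the lower number, so across the compounds shown, chain size does not shift the number in one fixed direction, and the pair of compound 2 and compound 4 goes against the earlier trend. Nothing measured here bears on why the two steps differ.

On these data alone, it remains open whether the number would keep falling if ethyl were shortened further or replaced by a cyclopropyl or hydroxyethyl group. A carboxylic acid or an amine at the end of this chain also remains untested among the compounds shown.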